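Phenyl in Place of Hydrogen: Estimating Compound 3

The source may hold more compounds than are shown below. What is called first, only, known or untested is meant among the compounds shown, and "the series" means these compounds.

Measured compounds:
Compound 1 `COc1cccc2c(OC(C)C)c(C(=O)Nc3nn[nH]n3)sc12` — in a functional assay for inhibition, with Homo sapiens as the target (a lower number here means a stronger inhibitor, a higher number a weaker inhibitor), compound 1 gives > 100000 nM.
Compound 2 `CC(C)Oc1c(C(=O)Nc2nn[nH]n2)sc2ccc(O)cc12` — in this assay compound 2 gives 47800 nM.

The value of compound 1 is a limit of this assay, not a number. Compound 2 is therefore the only compound here with a measured number in this assay, and that number is weak; one further value is a limit, as shown by the limit of > 100000 nM in this assay, at which 1 of the 2 values shown sits. Within the data shown here, no pair of these two compounds differs in one place, so no measured step can be read from them.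

Compound 3 `CC(C)Oc1c(C(=O)Nc2nn[nH]n2)sc2ccc(Oc3ccccc3)cc12` is not yet measured. It differs from compound 2 by phenyl in place of hydrogen on an oxygen on an aromatic ring. Without a measured step of this kind, the expectation rests only on the weak starting point of compound 2 at 47800 nM, and the step is expected to be modest, pointing toward a stronger inhibitor but possibly staying within the scatter. In this assay compound 3 is therefore expected to give about 20000 nM, between 5000 nM and 100000 nM, an estimated step of a 2.4-fold lower number from compound 2 to compound 3 (0.38 log units; beyond the scatter).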

Compound 3, half-maximal inhibitory concentration: > 100000 nM
Compound 3: no number, only a limit (the forecaster's own chance of this, stated with the estimate: 25%); at least 5.0-fold (0.69 log units) between middle value and limit.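

In this assay the change from hydroxy to phenoxy on this oxygen gives a weaker inhibitor, not a stronger one, with an at least 2.0-fold higher number from compound 2 to compound 3 (0.32 log units; beyond the scatter) as the smallest size the data allow. Going by these compounds, compound 3 carries a limit and not a number, so the true size of the step stays unknown. At this position, phenyl brings no gain in the one comparison available, and compound 2 remains the only compound with a measured number, which leaves little to compare: the limit of > 100000 nM in this assay, at which 2 of the 3 values shown sit.

The compounds shown leave open whether a methyl or a benzyl group on this oxygen would keep the activity of compound 2 or lose it too. They also leave open what an amine in place of the oxygen would do at this position.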